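This account rests on a few compounds, and the source may have more. Where it says the series, first, only, none or still open, it means among the compounds named here.

Series read in an ADME assay on L132 cells (Homo sapiens) for cytotoxicity, read by MTT assay, with a stated time of 72 h; on this read-out lower numbers stand for stronger inhibition and higher numbers for weaker inhibition:

- compound 1 `COc1ccc(OC)c(C2=C(c3cc(OC)c(OC)c(OC)c3)C(=O)CC2O[SiH2]C(C)(C)C)c1`: 100 ug/mL
- compound 2 `COc1cc(C2=C(c3ccccc3)C(O[SiH2]C(C)(C)C)CC2=O)cc(OC)c1OC`: > 100 ug/mL (a limit of the assay, not a number)
- compound 3 `COCOc1cc(C2=C(c3cc(OC)c(OC)c(OC)c3)C(=O)CC2O[SiH2]C(C)(C)C)ccc1OC`: 32 ug/mL

Compound 3 carries the lowest of the two actual numbers in this assay, and compound 1 is its nearest neighbour. The next analogue is compound 4 `COc1ccc(C2=C(c3cc(OC)c(OC)c(OC)c3)C(=O)CC2O[SiH2]C(C)(C)C)cc1O`, which differs from compound 3 by hydrogen in place of methoxymethyl on an oxygen on an aromatic ring, so methoxymethoxy becomes hydroxy.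

For the measured compounds named here, no measured step makes this exact change. The closest evidence comes from two steps that introduce the 4-methoxy-3-(methoxymethoxy)phenyl group: a 3.1-fold lower number from compound 1 to compound 3 (0.49 log units; beyond the scatter), and an at least 3.1-fold lower number from compound 2 to compound 3 (0.49 log units; beyond the scatter). Both show that the group at this place can shift the read-out, but neither tests the free hydroxy. A further shift of similar, modest size toward a lower number is therefore expected, with real doubt about its direction. The expected change is a 2.3-fold lower number from compound 3 to compound 4 (0.36 log units; beyond the scatter). For compound 4 the estimated value is 14 ug/mL, with an expected range of 3 ug/mL to 60 ug/mL.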

Compound 4, half-maximal inhibitory concentration: < 1 ug/mL
Compound 4 was reported as a limit (the forecaster's own chance of this, stated with the estimate: 5%); middle value at least 14-fold (1.14 log units) away from the limit.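

Working notes on the series: in this assay, replacing methoxymethyl with hydrogen on the oxygen on the aromatic ring gives an at least 32-fold lower number from compound 3 to compound 4 (1.50 log units; beyond the scatter). This far exceeds the earlier evidence for this ring substituent, a 3.1-fold lower number from compound 1 to compound 3 (0.49 log units; beyond the scatter), and shows that the free hydroxy and the methoxymethoxy group are not interchangeable here. The 3-hydroxy-4-methoxyphenyl group also separates clearly from the other two groups on the double-bonded ring carbon, with an at least 100-fold lower number from compound 1 to compound 4 (2.00 log units; beyond the scatter) and an at least 100-fold lower number from compound 2 to compound 4 (2.00 log units; beyond the scatter). The result for compound 4 is a limit of the assay, not a number: the limit of < 1 ug/mL in this assay, at which 1 of the 4 values shown sits.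

From the compounds shown here alone, the actual size of all three new steps therefore remains open. The compounds shown also leave open whether an amine or a carboxylic acid in place of the hydroxy would retain this shift.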